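A few compounds are considered here, and "the series" means these few. Any claim that something is new, unique, unknown or untested is made for them only; others in the source may bear on it.

The study rests on two measured compounds and one still awaiting measurement. Compound 1, `O=C(O)Cc1sc(NC(=O)c2ccccc2)nc1-c1ccc(Cl)cc1`, gives 520 nM in an in vitro assay on HEK385-7 cells for displacement of a labelled ligand from prostaglandin D2 receptor 2 (Homo sapiens); on this read-out lower numbers stand for stronger inhibition and higher numbers for weaker inhibition. Compound 2, `N#Cc1cc(-c2nc(C(c3ccc(F)cc3)c3ccc(F)cc3)sc2CC(=O)O)ccc1F`, gives 57 nM in this assay. Within the data shown here, of the two numbers known, compound 2 has the lower one, and its gap to compound 1 lies well beyond the usual scatter of repeated measurements. Compound 3, `CN(C)c1cc(-c2nc(C(c3ccc(F)cc3)c3ccc(F)cc3)sc2CC(=O)O)ccn1`, has not yet been measured in this assay. It differs from compound 2 in a single place: 2-(dimethylamino)pyridin-4-yl in place of 3-cyano-4-fluorophenyl on an aromatic carbon. Among the measured compounds shown here, no two measured compounds differ only in this exchange, so the data give no direct reading of what it does. Without such a comparison, only a small step is expected from compound 2 to compound 3 in this assay, toward weaker inhibition, and it may well stay within the scatter. The step expected is a 1.9-fold higher number from compound 2 to compound 3 (0.29 log units; within the scatter). Compound 3 is therefore estimated at 110 nM in this assay, with a range from 30 nM to 450 nM.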

Compound 3, half-maximal inhibitory concentration: 380 nM
Compound 3: middle estimate off by 3.5-fold (0.54 log units), on the low side; low and high end bracket the measured number.
By their numbers in this assay, from the lowest: compound 2; then compounds 3 and 1 (each within the scatter of the next).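

At this position, on the aromatic carbon next to the ring nitrogen and next to the ring atom that bears the carboxymethyl group, the aryl group is not interchangeable in this assay: putting 2-(dimethylamino)pyridin-4-yl in place of 3-cyano-4-fluorophenyl gives a 6.7-fold higher number from compound 2 to compound 3 (0.82 log units; beyond the scatter). The step appears even though the two groups match in heavy-atom count and each holds one six-membered aromatic ring, so matching these counts does not keep the number in place. Nothing measured here bears on why the number moves.

The exchange alters several things at once, with the nitrile and the fluorine leaving while a ring nitrogen and a dimethylamino group enter, so the compounds shown leave open which of these changes accounts for the step. A plain phenyl, a 3-cyanophenyl or a 4-fluorophenyl group at this position, or a pyridin-4-yl group bearing a methoxy group in place of the dimethylamino group, would be needed to pull these contributions apart.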